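The source may hold more compounds than are shown below. What is called first, only, known or untested is meant among the compounds shown, and "the series" means these compounds.

Of the compounds shown here, two sharing one core have been measured in a functional assay on MDA-MB-231 cells (Homo sapiens) for inhibition, read by MTT assay, with a stated time of 48 h; on this read-out lower numbers stand for stronger inhibition and higher numbers for weaker inhibition. Compound 1 (`COc1ccc(N(C)c2nc(C)nc3ccccc23)cc1C(=O)OCCC[Se]C#N`) gives 1180 nM. Compound 2 (`COc1ccc(N(C)c2nc(C)nc3ccccc23)cc1OCC[Se]C#N`) gives 13 nM, the lowest of the two numbers and so the stronger inhibition on this read-out. The step between them is a 91-fold lower number from compound 1 to compound 2 (1.96 log units; beyond the scatter), which lies beyond the scatter and is large. Compound 3 (`COc1ccc(N(C)c2nc(C)nc3ccccc23)cc1OCCN`) has not yet been measured in this assay. Its structure departs from that of compound 2 in one place: one nitrogen atom in place of a group of 3 heavy atoms (1 carbon, 1 nitrogen, 1 selenium; no ring), on a saturated chain carbon, two bonds along the chain from an oxygen on an aromatic ring. Within the data shown here, the single measured step bears on this change only indirectly. It shows that a change in the side chain can move the number a long way, but both of its compounds carry the group of 3 heavy atoms that compound 3 lacks, so the data hold no direct measure of replacing that group with amino. A higher number is nevertheless expected, because compound 2 stands at the low end at 13 nM. The expected change is a 12-fold higher number from compound 2 to compound 3 (1.06 log units; beyond the scatter), a clear step beyond the scatter but an uncertain one. For compound 3 the estimated value is 150 nM, with an expected range of 15 nM to 2000 nM.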

Compound 3, half-maximal inhibitory concentration: 682 nM
Estimate against measurement, compound 3: 4.5-fold (0.66 log units) below; the measured number falls inside the stated range.
By their numbers in this assay, from the lowest: compound 2; then compounds 3 and 1 (each within the scatter of the next).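

Among these compounds, replacing the group of 3 heavy atoms (1 carbon, 1 nitrogen, 1 selenium) with amino, on a saturated chain carbon, two bonds along the chain from an oxygen on an aromatic ring, gives a 52-fold higher number from compound 2 to compound 3 (1.72 log units; beyond the scatter) in this assay and is the first direct measure of this change. The low number of compound 2 is thus not kept once that group is gone, so the shared core and the oxygen-linked two-carbon chain do not carry it alone. The group is not enough by itself either: the comparison of the two other side chains gives a 1.7-fold lower number from compound 1 to compound 3 (0.24 log units; within the scatter) and so does not separate them, although compound 1 carries the group and compound 3 lacks it.

Nothing in the data gives a reason for these steps. The compounds shown leave open whether selenium or the nitrile matters more, which a thiocyanate, with sulfur in place of selenium, could help to separate, and whether a longer chain ending in the same selenium group, joined through the same oxygen, would keep the low number of compound 2.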